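A few compounds are considered here, and "the series" means these few. Any claim that something is new, unique, unknown or untested is made for them only; others in the source may bear on it.

Measured compounds:
Compound 1, `O=S(=O)(Nc1ccc(-c2nc3ccccc3o2)cc1)c1cccc(Cl)c1`; in an assay on isolated protein for inhibition of malate dehydrogenase, mitochondrial (Sus scrofa), with stated times of 45 min and 30 min (a higher number here means a weaker inhibitor, a lower number a stronger inhibitor), compound 1 gives > 63000 nM, a limit of the assay.
Compound 2, `O=S(=O)(Nc1ccc(-c2nc3ccccc3o2)cc1)c1cccc(C(F)(F)F)c1`; compound 2 gives > 63000 nM, again a limit.
Compound 3, `O=S(=O)(Nc1ccc(-c2nc3ccccc3o2)cc1)c1ccc(C(F)(F)F)cc1`; compound 3 gives > 63000 nM, also a limit.

Compound 1 thus stands only at a limit in this assay, and the two further values shown are limits as well, as the limit of > 63000 nM in this assay, at which 3 of the 3 values shown sit, records. For the measured compounds named here, the one measured step, trifluoromethyl in place of chloro on an aromatic carbon, is a step that the two limits leave unreadable from compound 1 to compound 2, so its size cannot be read.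

Compound 4, `Cc1ccccc1S(=O)(=O)Nc1ccc(-c2nc3ccccc3o2)cc1`, differs from compound 1 by 2-methylphenyl in place of 3-chlorophenyl on a sulfonyl sulfur. Going by the values given here, no measured step speaks to this change directly, and the only step available, a step that the two limits leave unreadable from compound 1 to compound 2, gives no size. Among the compounds with values here, since every value in this assay so far sits at the same limit, compound 4 is expected to stay there too, with no readable step beyond the scatter. The step from compound 1 to compound 4 is estimated as a step that the limit leaves unreadable from compound 1 to compound 4. Compound 4 is accordingly estimated at 90000 nM in this assay, with a range from 30000 nM to 300000 nM.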

Compound 4, half-maximal inhibitory concentration: > 63000 nM
Compound 4 ended at the assay's limit (the forecaster's own chance of this, stated with the estimate: 85%); the middle value lies beyond the limit too.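

The step between compound 1 and compound 4 cannot be read in this assay, as both compounds stand at a limit: the limit of > 63000 nM in this assay, at which 4 of the 4 values shown sit.

The compounds shown leave open whether any group on the sulfonyl sulfur of the shared core gives a measurable inhibition in this assay.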